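A few compounds are considered here, and "the series" means these few. Any claim that something is new, unique, unknown or untested is made for them only; others in the source may bear on it.

Two amides on the shared core have been measured so far. Compound 1 `CC(C)C(=O)N1CC2CC(C1)N2` gives 130 nM in an assay on SH-EP1 cells for displacement of a labelled ligand from Neuronal acetylcholine receptor; alpha4/beta2 (Homo sapiens), read by scintillation counting; a lower number here means a stronger inhibitor, a higher number a weaker inhibitor. Compound 2 `O=C(C1CCCC1)N1CC2CC(C1)N2` gives 160 nM in this assay. Compound 1 has the lower of the two numbers, but the two values lie within the scatter of each other, so nothing separates them on these data. Compound 3 `C[C@@H]1C[C@@H]1C(=O)N1CC2CC(C1)N2` has not yet been measured. It differs from compound 1 by a group of 4 heavy atoms (4 carbon; one three-membered non-aromatic ring of carbon only) in place of a group of 3 heavy atoms (3 carbon; no ring), on a carbonyl carbon; the group that enters carries two defined stereocentres. Compound 1 and compound 2 differ only in the group on the carbonyl carbon and give numbers within the scatter of each other, so that position has not yet moved the number. For compound 3 a step of about a 1.2-fold lower number from compound 1 to compound 3 (0.07 log units; within the scatter) from compound 1 is expected, within or barely beyond the scatter. Compound 3 is estimated at 110 nM in this assay, with a range from 45 nM to 270 nM.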

Compound 3, inhibition constant: 22 nM
Beside the measured number, compound 3's estimate is 5.0-fold (0.70 log units) above it, and the stated range ends above it.
By their numbers in this assay, from the lowest: compound 3; then compounds 1 and 2 (each within the scatter of the next).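

The group on the carbonyl carbon can move the number after all: in this assay, replacing isopropyl with the group holding one three-membered non-aromatic ring of carbon only and two defined stereocentres gives a 5.9-fold lower number from compound 1 to compound 3 (0.77 log units; beyond the scatter). A ring at this position does not by itself set a compound apart from compound 1, as compound 2 also carries one there and stays within the scatter of compound 1, so the result depends on which ring-bearing group is present. Nothing available accounts for the size of this step.

The compounds shown do not separate the contribution of the ring from that of the ring's methyl group or of the two defined stereocentres, a question that a plain cyclopropyl and the other stereoisomers of this group would address. Going by these compounds, how a cyclobutyl or a phenyl on the carbonyl carbon would read also remains open.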